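A few compounds are considered here, and "the series" means these few. Any claim that something is new, unique, unknown or untested is made for them only; others in the source may bear on it.

Measured compounds in a functional assay on A549 cells (Homo sapiens) for inhibition, read by MTT assay, with a stated time of 72 h; a lower number here means a stronger inhibitor, a higher number a weaker inhibitor:
Compound 1 `CN(C(=O)NC(=O)c1cccc(C(F)(F)F)c1)c1nc(C(F)(F)F)c(C(=O)N/N=C/c2ccc(C(F)(F)F)cc2)s1`: 6.2 ug/mL
Compound 2 `CN(C(=O)NC(=O)c1cccc(C(F)(F)F)c1)c1nc(C(F)(F)F)c(C(=O)N/N=C/c2ccccc2C(F)(F)F)s1`: 12.1 ug/mL
Compound 3 `CN(C(=O)NC(=O)c1ccccc1)c1nc(C(F)(F)F)c(C(=O)N/N=C/c2cccc([N+](=O)[O-])c2)s1`: 20.7 ug/mL

Among these three numbers compound 2 holds the second highest, but its gaps to compound 3 and to compound 1 both lie within the usual scatter, so no order among the three can be read from them. Compound 4 `CN(C(=O)NC(=O)c1cccc([N+](=O)[O-])c1)c1nc(C(F)(F)F)c(C(=O)N/N=C/c2ccccc2C(F)(F)F)s1` differs from compound 2 in one place: nitro in place of trifluoromethyl on an aromatic carbon. Among the measured compounds shown here, the only measured step, a 2.0-fold higher number from compound 1 to compound 2 (0.29 log units; within the scatter), alters a different part of the molecule and stayed within the scatter; no measured pair changes the group on this ring, so nothing in the data points to a direction. The expected step is a 1.1-fold higher number from compound 2 to compound 4 (0.03 log units; within the scatter), none beyond the scatter. Compound 4 is estimated at 13 ug/mL, with a range from 5 ug/mL to 32 ug/mL.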

Compound 4, half-maximal inhibitory concentration: 5.45 ug/mL
Beside the measured number, compound 4's estimate is 2.4-fold (0.38 log units) above it; the measured number falls inside the stated range.
By their numbers in this assay, from the lowest: compounds 4, 1, 2 and 3 (each within the scatter of the next, the first and the last beyond it).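

Among the compounds shown here, replacing the (3-(trifluoromethyl)phenyl)carbonyl end with (3-nitrophenyl)carbonyl gives the first measured change on this ring in this assay: a 2.2-fold lower number from compound 2 to compound 4 (0.35 log units; beyond the scatter), a modest step but one beyond the usual scatter. The group on this ring can therefore shift the number, and in this pair the nitro compound is the stronger inhibitor. No available evidence explains the step. As far as these compounds go, how an amine or a carboxylic acid would behave at this place remains open. So does whether the swap gives a similar step when the other end of the molecule carries a different group.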